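From pyrrolidin-1-yl to 4-(pyrrolidin-1-yl)piperidin-1-yl on the shared core

This account rests on a few compounds, and the source may have more. Where it says the series, first, only, none or still open, it means among the compounds named here.

Among the measured compounds shown here, in a functional assay on PC-3 cells (Homo sapiens) for antiproliferative activity, read by MTT assay, with a stated time of 96 h (on this read-out higher numbers stand for weaker inhibition and lower numbers for stronger inhibition), compound 1 (`CCN1CCN(c2ccc3nnnc(Nc4cccc(OC(F)(F)F)c4)c3n2)CC1`) gives 16900 nM as the only number so far. Compound 2 (`FC(F)(F)Oc1cccc(Nc2nnnc3ccc(N4CCCC4)nc23)c1`) gives > 100000 nM as a limit of the assay. Compound 3 (`CC(C)(C)OC(=O)N1CCC(CNc2ccc3nnnc(Nc4cccc(OC(F)(F)F)c4)c3n2)CC1`) gives > 100000 nM as a limit too. Compound 2 thus sits at the limit of > 100000 nM in this assay, at which 2 of the 3 values shown sit, and has no number of its own.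

The change to compound 4 (`FC(F)(F)Oc1cccc(Nc2nnnc3ccc(N4CCC(N5CCCC5)CC4)nc23)c1`) is 4-(pyrrolidin-1-yl)piperidin-1-yl in place of pyrrolidin-1-yl on an aromatic carbon and puts 4-(pyrrolidin-1-yl)piperidin-1-yl in place of pyrrolidin-1-yl on an aromatic carbon next to the ring nitrogen. For the measured compounds named here, the one measured step at this place is an at least 5.9-fold higher number from compound 1 to compound 2 (0.77 log units; beyond the scatter) with pyrrolidin-1-yl in place of 4-ethylpiperazin-1-yl. Read backwards, that step points to a lower number for compound 4 in this assay by a similar margin. The support is thin, since compound 3 also carries a six-membered non-aromatic ring in its substituent and still stops at a limit. The estimate amounts to an at least 3.3-fold lower number from compound 2 to compound 4 (0.52 log units; beyond the scatter) as an expected step. Compound 4 is estimated at 30000 nM with an expected range from 8000 nM to 100000 nM in this assay.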

Compound 4, half-maximal inhibitory concentration: 8160 nM
The estimate for compound 4 lay 3.7-fold (0.57 log units) above the measured number, and the stated range covers the measured number.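

At this place on the shared core, an aromatic carbon next to the ring nitrogen, this assay shows that pyrrolidin-1-yl need not be replaced outright: carrying it on a piperidine ring as 4-(pyrrolidin-1-yl)piperidin-1-yl gives an at least 12-fold lower number from compound 2 to compound 4 (1.08 log units; beyond the scatter). Compound 2 has only a limit, so this step is a bound and not an exact size: the limit of > 100000 nM in this assay, at which 2 of the 4 values shown sit. The new group also improves on the 4-ethylpiperazin-1-yl group, with a 2.1-fold lower number from compound 1 to compound 4 (0.32 log units; beyond the scatter), so the gain from compound 2 is not merely a return to the level of compound 1.

The compounds shown do not separate the effect of the added ring from that of the added nitrogen. A plain piperidin-1-yl or a morpholin-4-yl at this place would help to tell the two apart.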